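Swapping trifluoromethyl for methyl on a potent nicotinic ligand

The compounds below may be only part of what the source reports. "The series", "measured", "known", "first", "only" and "open" are said of these compounds alone.

Measured so far:
compound 1, `CN1CCC[C@H]1COc1cncc(-c2cccc(N)c2)c1`, in an assay on membranes from brain for binding affinity to Neuronal acetylcholine receptor; alpha4/beta2 (Rattus norvegicus) (a lower number here means a stronger inhibitor, a higher number a weaker inhibitor), compound 1 gives 0.43 nM
compound 2, `CN1CCC[C@H]1COc1cncc(-c2ccc(C(F)(F)F)cc2)c1`, in this assay compound 2 gives 0.15 nM

Of the two, compound 2 has the lower number; its nearest neighbour, compound 1, gives a higher number, and that gap is beyond the scatter. Compound 3, `Cc1ccc(-c2cncc(OC[C@@H]3CCCN3C)c2)cc1`, differs from compound 2 by methyl in place of trifluoromethyl on an aromatic carbon. Going by the values given here, no measured pair shows this change, so its effect is unknown. The expected step from compound 2 to compound 3 in this assay is a 2.0-fold higher number from compound 2 to compound 3 (0.30 log units; within the scatter), a shift toward a weaker binder but near the scatter. Compound 3 is estimated at 0.3 nM, between 0.1 nM and 1 nM.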

Compound 3, inhibition constant: 0.13 nM
For compound 3 the middle estimate is 2.3-fold (0.36 log units) above the measured one, within the range that was stated.
By their numbers in this assay, from the lowest: compounds 3 and 2 (each within the scatter of the next); then compound 1.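

In this assay putting methyl in place of trifluoromethyl, on an aromatic carbon para to a large group, gives a 1.2-fold lower number from compound 2 to compound 3 (0.06 log units; within the scatter) and so no real change: the fluorine atoms are not needed for binding this tight. Putting 4-methylphenyl in place of 3-aminophenyl gives a 3.3-fold lower number from compound 1 to compound 3 (0.52 log units; beyond the scatter) and this step is a real gain, though the group and its place on the ring change together. Nothing available explains the size of either step.

Still open, on these data alone, is whether this position would hold the same strength with a chlorine atom, a carboxylic acid or a longer chain such as ethyl.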